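The source may report more compounds than this note shows. Statements on the series, on what has been measured and on what is new or still open speak of the compounds shown alone.

Measured so far:
- compound 1 `COc1cc(-c2cc(/C=C/C(=O)c3ccc(N)cc3)[nH]n2)cc(OC)c1OC` — 34900 nM
- compound 2 `COc1cc(-c2cc(/C=C/C(=O)c3ccc(Cl)c(Cl)c3)[nH]n2)cc(OC)c1OC` — a limit only

Among the compounds with values here, in a functional assay on OVCAR-8 cells (Homo sapiens) for inhibition, read by sulforhodamine B assay, with a stated time of 48 h (a lower number here means that less compound is tolerated, a higher number that more compound is tolerated), compound 1 gives 34900 nM, the only number reported in this assay. For compound 2 this assay gives only a limit, > 100000 nM. Within the data shown here, the one measured step, an at least 2.8-fold higher number from compound 1 to compound 2 (0.45 log units; beyond the scatter), ends at the limit of > 100000 nM in this assay, at which 1 of the 2 values shown sits, and is therefore known only as a lower bound.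

Compound 3 `COc1ccc(-c2cc(/C=C/C(=O)c3ccc(N)cc3)[nH]n2)cc1OC` differs from compound 1 as follows: hydrogen in place of methoxy on an aromatic carbon. Among the measured compounds shown here, no measured step touches this part of the structure; the step from compound 1 to compound 2 changes a different group on the carbonyl carbon and does not bear on a methoxy loss. Without a relevant comparison, a step within the scatter or a small rise in this assay is the working expectation for compound 3. The estimate for compound 3 is 50000 nM, between 15000 nM and 150000 nM; the expected step of a 1.4-fold higher number from compound 1 to compound 3 (0.16 log units; within the scatter) is small.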

Compound 3, concentration lethal to 50% of the cells: 39000 nM
Beside the measured number, compound 3's estimate is 1.3-fold (0.11 log units) above it; the range from low to high includes it.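

Hydrogen in place of methoxy on an aromatic carbon gives a 1.1-fold higher number from compound 1 to compound 3 (0.05 log units; within the scatter) in this assay, so the two compounds cannot be told apart in this read-out. Within the data shown here, the one earlier step concerned only the group on the carbonyl carbon; this one is the first reading on the six-membered aromatic ring of carbon only, and there the loss of a methoxy group, ortho to a methoxy group and meta to a large group, stays within the scatter. Compound 2 remains a limit and not a number: the limit of > 100000 nM in this assay, at which 1 of the 3 values shown sits.

Open, going by these compounds, is whether a hydroxyl group, an ethoxy group or a longer alkoxy chain at this position would also stay within the scatter. Also open, on these data alone, is whether the methoxy loss reads the same with 3,4-dichlorophenyl on the carbonyl carbon in place of 4-aminophenyl.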